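The source may hold more compounds than are shown below. What is called first, only, known or untested is meant among the compounds shown, and "the series" means these compounds.

In an assay on cells for inhibition of MAP kinase-interacting serine/threonine-protein kinase 2 (Homo sapiens), read by mobility shift assay, with stated times of 10 min and 60 min, in the presence of a further agent that is not named here (a lower number here means a stronger inhibitor, a higher number a weaker inhibitor), compound 1 `CC(C)Oc1cc(-c2cncc(-c3cnn(C(C)C)c3)c2)ccc1C(N)=O` gives 42 nM. Of the two numbers in hand it is the lowest, but the nearest, compound 2 `CC(C)Oc1cc(-c2cncc(-c3cnn(C4CCOC4)c3)c2)ccc1C(N)=O`, gives 44 nM in this assay, and the step of a 1.0-fold higher number from compound 1 to compound 2 (0.02 log units; within the scatter) means the two cannot be told apart. Compound 3 `CNC(=O)c1cncc(-c2ccc(C(N)=O)c(OC(C)C)c2)c1` differs from compound 1 in a single place: methylcarbamoyl in place of 1-isopropyl-1H-pyrazol-4-yl on an aromatic carbon. Among the measured compounds shown here, no measured step touches this change; the only step in hand, from oxolan-3-yl in place of isopropyl on an aromatic nitrogen, exchanges a group on the ring that is now removed and was itself within the scatter, so it gives no direction for the loss of that whole ring. With so little to rest on, compound 3 is expected to give 250 nM in this assay, in a range from 50 nM to 1500 nM, and the expected step of a 6.0-fold higher number from compound 1 to compound 3 (0.77 log units; beyond the scatter) is set wide for that reason.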

Compound 3, half-maximal inhibitory concentration: 630 nM
Estimate against measurement, compound 3: 2.5-fold (0.40 log units) below, and the stated range covers the measured number.
By their numbers in this assay, from the lowest: compounds 1 and 2 (each within the scatter of the next); then compound 3.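

In this assay, the aromatic carbon two atoms from the ring nitrogen proves far more sensitive to change than the earlier pair suggested: the exchange of 1-isopropyl-1H-pyrazol-4-yl for methylcarbamoyl is a 15-fold higher number from compound 1 to compound 3 (1.18 log units; beyond the scatter). By contrast, the exchange on the aromatic nitrogen of that same substituent is a 1.0-fold higher number from compound 1 to compound 2 (0.02 log units; within the scatter), so replacing the whole substituent at this position has a large effect, whereas that exchange on its nitrogen has none that can be read. Nothing available accounts for the size of this loss.

Among the compounds shown here, the single change removes the five-membered aromatic ring and also brings in a carbonyl and an amide hydrogen, and these compounds cannot separate those parts. As far as these compounds go, it remains open how an unsubstituted pyrazole, an amine or a longer chain on the amide nitrogen would read at this position.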